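Replacing 2-methylphenyl with 4-chlorophenyl in compound 3

The compounds below may be only part of what the source reports. "The series", "measured", "known", "first", "only" and "open" are said of these compounds alone.

Measured so far in an ADME assay on BHK-21 cells (Mesocricetus auratus) for cytotoxicity, read by MTT assay, with a stated time of 72 h; on this read-out lower numbers stand for higher toxicity in this test and higher numbers for lower toxicity in this test (two compounds):
Compound 1 `NS(=O)(=O)c1ccc(N2N=C(c3ccc(Oc4ccccc4)cc3)CC2c2cccc(F)c2)cc1` gives 10000 nM
Compound 2 `Cc1ccccc1C1CC(c2ccc(Oc3ccccc3)cc2)=NN1c1ccc(S(N)(=O)=O)cc1` gives 7000 nM

Going by the values given here, compound 2 stands within the scatter of compound 1, the only other compound measured, so these two values set no order. Compound 3 `NS(=O)(=O)c1ccc(N2N=C(c3ccc(Oc4ccccc4)cc3)CC2c2ccc(Cl)cc2)cc1` has not yet been measured. It keeps the shared core and carries 4-chlorophenyl in place of 2-methylphenyl on a saturated ring carbon and nothing else differs. Among the compounds with values here, only one measured step bears on this change. That step is a 1.4-fold lower number from compound 1 to compound 2 (0.15 log units; within the scatter) and it swapped 3-fluorophenyl for 2-methylphenyl on the same saturated ring carbon. Within the data shown here, one step is thin evidence, and no compound with 4-chlorophenyl has been measured. On that single step, no change beyond the scatter is expected in this assay and no firm direction can be given. The expected result is a 1.1-fold higher number from compound 2 to compound 3 (0.06 log units; within the scatter) and this estimate stays within the scatter. Compound 3 is estimated at 8000 nM (expected range 4000 nM to 15000 nM).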

Compound 3, half-maximal cytotoxic concentration: 7000 nM
The estimate for compound 3 lay 1.1-fold (0.06 log units) above the measured number; measured number inside the range.
By their numbers in this assay, from the lowest: compounds 2, 3 and 1 (each within the scatter of the next).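

In this assay, the 4-chlorophenyl group gives no change at the digits printed from compound 2 to compound 3 (within the scatter), and a 1.4-fold lower number from compound 1 to compound 3 (0.15 log units; within the scatter). Going by these compounds alone, the earlier pair offered only one exchange on this saturated ring carbon, whereas these steps show that 3-fluorophenyl, 2-methylphenyl and 4-chlorophenyl all stay within the scatter of one another, so this set of three substituted phenyl groups cannot be ordered by this read-out. The exchange of 2-methylphenyl for 4-chlorophenyl keeps the heavy-atom count, the single six-membered aromatic ring and the absence of hydrogen-bond donors, acceptors and net charge, and the number stays the same at the digits printed; no measurement here offers an explanation for this result.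

The compounds shown leave open whether a group of another kind on this carbon, such as a phenyl ring carrying an amine or a carboxylic acid, or a longer chain in place of the ring, would move the number beyond the scatter. They also cannot say whether the same lack of separation would hold if the 4-sulfamoylphenyl group or another part of the shared core were changed.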